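Compound 3 to compound 4: chlorophenyl positional change

This account rests on a few compounds, and the source may have more. Where it says the series, first, only, none or still open, it means among the compounds named here.

Compound 3 `CC1=CC[C@H](C(C)(C)NC(=S)N/N=C/c2cccc(Cl)c2)CC1` gives 39800 nM in a functional assay on UACC-62 cells (Homo sapiens) for inhibition, read by sulforhodamine B assay, with a stated time of 48 h (on this read-out lower numbers stand for stronger inhibition of growth and higher numbers for weaker inhibition of growth), and among the numbers in hand it stands highest of the two. Compound 1 `CC1=CC[C@H](C(C)(C)NC(=S)N/N=C/c2ccccc2O)CC1` gives 10800 nM in this assay, so the step of a 3.7-fold higher number from compound 1 to compound 3 (0.57 log units; beyond the scatter) lies beyond the scatter. Compound 2 `CC1=CC[C@H](C(C)(C)NC(=S)N/N=C/c2ccc(N(C)C)cc2)CC1` gives > 100000 nM in this assay; this is a limit of the assay and not a number, namely (the limit of > 100000 nM in this assay, at which 1 of the 3 values shown sits).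

Compound 4 `CC1=CC[C@H](C(C)(C)NC(=S)N/N=C/c2ccc(Cl)cc2)CC1` is not yet measured. It differs from compound 3 by 4-chlorophenyl in place of 3-chlorophenyl on a carbon with a double bond to nitrogen. Within the data shown here, no measured step moves a chlorine from one position of the ring to another; the single measured step exchanges a hydroxyl group for a chlorine and therefore does not bear directly on the present change. With the chlorine retained and only its position on the ring altered, no step beyond the scatter is expected in this assay, in either direction. Compound 4 is therefore expected to give about 40000 nM in this assay, with a range from 15000 nM to 100000 nM. The step this estimate means, a 1.0-fold higher number from compound 3 to compound 4 (0.00 log units; within the scatter), is expected to remain within the scatter.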

Compound 4, concentration for total growth inhibition: > 100000 nM
Compound 4: no number, only a limit; the forecaster's own chance of this, stated with the estimate: 15%; at least 2.5-fold (0.39 log units) between middle value and limit.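

Moving the chlorine is not a neutral change in this assay: 4-chlorophenyl in place of 3-chlorophenyl, on the same carbon with a double bond to nitrogen, gives an at least 2.5-fold higher number from compound 3 to compound 4 (0.40 log units; beyond the scatter), so the place of the chlorine on the ring counts here even though the two groups hold the same atoms. That reading is a limit and not a number, and measured against the 2-hydroxyphenyl group the change reads as an at least 9.2-fold higher number from compound 1 to compound 4 (0.96 log units; beyond the scatter). Compound 4 now shares its limit with compound 2, so the step between those two cannot be read, and neither of them carries a number: the limit of > 100000 nM in this assay, at which 2 of the 4 values shown sit.

What the compounds shown leave open is whether the lower number of compound 1 goes with the hydroxyl group itself or with its place on the ring. Also open, from the compounds shown here alone, is how a methoxy group or a carboxylic acid would read in place of the chlorine of compound 3 in this assay.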